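The source may hold more compounds than are shown below. What is called first, only, known or untested is meant among the compounds shown, and "the series" means these compounds.

Measured compounds:
compound 1 `NC(=O)c1cc(C(N)=O)n(-c2cccc(-c3ccccc3OC(F)(F)F)c2)n1` — 554 nM
compound 2 `NC(=O)c1cc(C(N)=O)n(-c2cccc(-c3ccccc3C(F)(F)F)c2)n1` — 915 nM

Both were tested in an assay on isolated protein for inhibition of sodium channel protein type 10 subunit alpha (Homo sapiens); a lower number here means a stronger inhibitor, a higher number a weaker inhibitor. Compound 1 holds the lower of the two numbers, but the step of a 1.7-fold higher number from compound 1 to compound 2 (0.22 log units; within the scatter) lies within the scatter, so the two compounds cannot be told apart. Compound 3 `NC(=O)c1cc(C(N)=O)n(-c2cccc(-c3c(F)cccc3OC(F)(F)F)c2)n1` differs from compound 1 by fluoro in place of hydrogen on an aromatic carbon. For the measured compounds named here, the single measured step concerns a different group and is itself within the scatter, so it offers no guide to this change. Compound 3 is therefore expected to give 500 nM (range 200 nM to 1500 nM), an estimated step of a 1.1-fold lower number from compound 1 to compound 3 (0.04 log units; within the scatter) that is not expected to exceed the scatter.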

Compound 3, half-maximal inhibitory concentration: 802 nM
Compound 3: the middle estimate sits 1.6-fold (0.21 log units) below what was measured; the measured number falls inside the stated range.
By their numbers in this assay, from the lowest: compounds 1, 3 and 2 (each within the scatter of the next).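

In this assay, fluoro in place of hydrogen on an aromatic carbon, ortho to a large group and meta to a trifluoromethoxy group, gives a 1.4-fold higher number from compound 1 to compound 3 (0.16 log units; within the scatter). This position therefore accepts a single fluoro with no change that can be told from the scatter, which the earlier step, concerning a different group, could not show. Nothing available here bears on why this is so. Going by these compounds, whether chloro, methoxy or an amine at this position would shift the number beyond the scatter stays open. So does whether fluoro here would behave the same way in compound 2, which carries trifluoromethyl.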